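Fluoro Added to the Higher of Two Compounds

This account rests on a few compounds, and the source may have more. Where it says the series, first, only, none or still open, it means among the compounds named here.

compound 1 `O=C1NC(=O)C(c2ccc(-c3ccc4ccccc4c3)[nH]c2=O)O1` gives 32%
compound 2 `CC(C)C1(c2ccc(-c3ccc4ccccc4c3)[nH]c2=O)OC(=O)NC1=O` gives 83%

In an in vivo ADME assay on the whole organism (strain Sprague-Dawley) for pharmacokinetics, with Rattus norvegicus as the target, at a dose of 2 mg/kg by the oral route (a lower number here means that a smaller share of the oral dose reaches the circulation, a higher number that a larger share of the oral dose reaches the circulation), compound 2 stands highest of the two measured compounds at 83% and serves as the starting point here. Going by the values given here, the only measured step is a number 51 percentage points higher from compound 1 to compound 2 (beyond the scatter) and is large, lying beyond the scatter, with isopropyl in place of hydrogen on a saturated ring carbon. Compound 3 `CC(C)C1(c2ccc(-c3ccc4cccc(F)c4c3)[nH]c2=O)OC(=O)NC1=O` keeps that isopropyl and differs from compound 2 by fluoro in place of hydrogen on an aromatic carbon in one change, fluoro in place of hydrogen on an aromatic carbon. The measured step concerns another group in another place, and no fluoro change has been measured, so no step beyond the scatter is expected in this assay on this evidence. The expected step is a number 5 percentage points lower from compound 2 to compound 3 (within the scatter) and remains only an estimate. For compound 3 the estimated value is 78% with an expected range from 58% to 95% for the coming measurement.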

Compound 3, oral bioavailability: 93%
Compound 3: middle estimate off by 15 percentage points, on the low side, and the stated range covers the measured number.
By their numbers in this assay, from the lowest: compound 1; then compounds 2 and 3 (each within the scatter of the next).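

Fluoro in place of hydrogen on this aromatic carbon, ortho to a fused ring, gives a number 10 percentage points higher from compound 2 to compound 3 (within the scatter), so this assay cannot tell compound 2 and compound 3 apart. The earlier step concerned only a saturated ring carbon, whereas this one shows that, with the isopropyl kept, this aromatic carbon can carry fluoro while oral bioavailability stays within the scatter. Nothing shown here offers an explanation for this result.

The compounds shown leave open whether a larger or different group on this carbon, such as methoxy, an amine or a carboxylic acid, would also stay within the scatter. They also leave open whether fluoro would give the same result on another carbon of this ring, or in a compound with hydrogen in place of the isopropyl.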